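The compounds below may be only part of what the source reports. "The series", "measured", "known", "first", "only" and "open" are said of these compounds alone.

Three compounds share one core and differ only in the ring that hangs from the alkyne. Compound 1 `Cc1nc(C#Cc2cc(C#N)cc([N+](=O)[O-])c2)cs1` gives 2.63 nM in a functional assay on HEK293 cells for antagonist activity at metabotropic glutamate receptor 5 (Rattus norvegicus), read by calcium flux; a higher number here means a weaker inhibitor, a lower number a stronger inhibitor. Compound 2 `Cc1cccc(C#Cc2cc(C#N)cc([N+](=O)[O-])c2)n1` gives 3.68 nM in this assay. Compound 3 `Cc1ccc(C#Cc2cc(C#N)cc([N+](=O)[O-])c2)nc1` gives 2.64 nM in this assay, and its number sits alongside those of compound 1 and compound 2: the three values lie within the usual scatter of one another, so none of them can be set apart from the rest on these figures alone.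

Compound 4 `N#Cc1cc(C#Cc2ccccn2)cc([N+](=O)[O-])c1` follows from compound 3 by a single change: hydrogen in place of methyl on an aromatic carbon. For the measured compounds named here, no pair among the three measured compounds differs in that way, so there is no measured step to lean on. Across the three measured compounds, swapping one methyl-bearing ring for another left the readings within scatter, which argues against a large effect from a small change at the ring. Compound 4 is therefore expected to stay close to compound 3, with at most a modest weakening, a step of a 1.9-fold higher number from compound 3 to compound 4 (0.28 log units; within the scatter). The estimate for compound 4 is 5 nM, with a range from 2 nM to 14 nM.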

Compound 4, half-maximal inhibitory concentration: 1.32 nM
For compound 4 the middle estimate is 3.8-fold (0.58 log units) above the measured one; the measured number lies below the stated range.
By their numbers in this assay, from the lowest: compounds 4, 1, 3 and 2 (each within the scatter of the next, the first and the last beyond it).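

Methyl is not needed at this position: on the carbon two atoms from the ring nitrogen and para to a large group, hydrogen in its place gives a 2.0-fold lower number from compound 3 to compound 4 (0.30 log units; within the scatter), so the unsubstituted ring holds its place in this assay with no sign of a loss. The same exchange of methyl for hydrogen at the methyl position of compound 2 gives a 2.8-fold lower number from compound 2 to compound 4 (0.45 log units; beyond the scatter), a modest step and the only one of the three that lies beyond the scatter, whereas pyridin-2-yl in place of 2-methyl-1,3-thiazol-4-yl on the triple-bonded carbon gives a 2.0-fold lower number from compound 1 to compound 4 (0.30 log units; within the scatter), so compound 4 cannot be separated from the thiazole of compound 1 on these numbers. Nothing available here offers an independent measurement that would explain these steps.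

The compounds shown leave open how far this carbon accepts anything larger than methyl, such as an ethyl, a methoxy group or an amine. They also leave open what happens in this assay when the nitrile or the nitro group of the shared core is replaced, for instance by a chlorine or a carboxylic acid, since all four compounds carry both groups.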